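The source may hold more compounds than are shown below. What is called first, only, known or untested is meant among the compounds shown, and "the series" means these compounds.

Compound 3 `CC(C(=O)NCc1ccc(C(F)(F)Cl)nc1OCc1ccccc1)c1ccc(NS(C)(=O)=O)c(F)c1` gives 0.9 nM in an assay on CHO cells for antagonist activity at transient receptor potential cation channel subfamily V member 1 (Homo sapiens), read by FLIPR; a lower number here means a stronger inhibitor, a higher number a weaker inhibitor. Compound 2 `CC(C(=O)NCc1ccc(C(F)(F)Cl)nc1OC1CCCCC1)c1ccc(NS(C)(=O)=O)c(F)c1` gives 0.9 nM, and compound 1 `CC1CCN(c2nc(C(F)(F)Cl)ccc2CNC(=O)C(C)c2ccc(NS(C)(=O)=O)c(F)c2)CC1` gives 0.3 nM; so compound 3 stands level with compound 2 at the highest numbers of the three, as shown by no change at the digits printed from compound 2 to compound 3 (within the scatter), while a 3.0-fold higher number from compound 1 to compound 3 (0.48 log units; beyond the scatter) sets compound 1 apart. Compound 4 `CC(C(=O)NCc1ccc(C(F)(F)Cl)nc1OCc1ccccn1)c1ccc(NS(C)(=O)=O)c(F)c1` differs from compound 3 by pyridin-2-yl in place of phenyl on a saturated chain carbon bound to an oxygen on an aromatic ring. Among the compounds with values here, the only measured step in this part of the molecule, no change at the digits printed from compound 2 to compound 3 (within the scatter), was flat, and no step compares a phenyl with a pyridin-2-yl, so the change is expected to stay within the scatter in this assay, as a 1.1-fold higher number from compound 3 to compound 4 (0.05 log units; within the scatter). Compound 4 is therefore estimated at 1 nM, within 0.4 nM to 2.5 nM.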

Compound 4, inhibition constant: 4.2 nM
Estimate against measurement, compound 4: 4.2-fold (0.62 log units) below; measured number above the stated range.
By their numbers in this assay, from the lowest: compound 1; then compounds 2 and 3 (each within the scatter of the next); then compound 4.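

In this assay the group on the oxygen proves not to be indifferent: pyridin-2-yl in place of phenyl gives a 4.7-fold higher number from compound 3 to compound 4 (0.67 log units; beyond the scatter) even though the cyclohexyl and benzyl groups had read alike there. The (pyridin-2-yl)methyl group shows a 4.7-fold higher number from compound 2 to compound 4 (0.67 log units; beyond the scatter) against cyclohexyl, and (pyridin-2-yl)methoxy shows a 14-fold higher number from compound 1 to compound 4 (1.15 log units; beyond the scatter) against 4-methylpiperidin-1-yl, the widest gap in the set. No measurement here accounts for this step. From the compounds shown here alone, whether pyridin-3-yl or pyridin-4-yl would read like pyridin-2-yl or like phenyl remains open, as does the reading of a longer chain between the oxygen and the ring.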